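A Nitro Group Replaces Carbamoyl in Compound 4

A few compounds are considered here, and "the series" means these few. Any claim that something is new, unique, unknown or untested is made for them only; others in the source may bear on it.

Three close relatives share one core and differ only in a single group on a benzene ring. Compound 1 `Cc1cc(NC(=O)Nc2ccccc2F)c2ccccc2n1` carries a fluoro group there. In an ADME assay on HepG2 cells (Homo sapiens) for cytotoxicity, with a stated time of 72 h (on this read-out higher numbers stand for an effect only at larger amounts of compound and lower numbers for an effect already at smaller amounts), compound 1 gives only a limit, > 25000 nM. Compound 2 `CSc1ccccc1NC(=O)Nc1cc(C)nc2ccccc12` carries a methylsulfanyl group in its place; in this assay compound 2 likewise gives only a limit, > 25000 nM. Compound 3 `Cc1cc(NC(=O)Nc2ccccc2C(N)=O)c2ccccc2n1` carries a carbamoyl group; in this assay compound 3 also reaches only a limit, > 25000 nM. Because of the limit of > 25000 nM in this assay, at which 3 of the 3 values shown sit, none of the steps between them can be read: a step that the two limits leave unreadable from compound 1 to compound 2, a step that the two limits leave unreadable from compound 1 to compound 3 and a step that the two limits leave unreadable from compound 2 to compound 3 all remain of unknown size. Compound 3 therefore stands at the same limit as the other two, at the edge of what the assay can report.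

Compound 4 `Cc1cc(NC(=O)Nc2ccccc2[N+](=O)[O-])c2ccccc2n1` differs from compound 3 by one change: nitro in place of carbamoyl on an aromatic carbon. For the measured compounds named here, no measured step shows what this exchange does, since every comparison available is hidden by the same limit. With three neighbours all showing no effect up to the limit, compound 4 is expected to behave alike, and its step that the limit leaves unreadable from compound 3 to compound 4 is estimated to lie within the scatter. Compound 4 is estimated at 40000 nM, in a range from 15000 nM to 150000 nM, most likely again reported only as a limit.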

Compound 4, half-maximal effective concentration: > 25000 nM
Compound 4: no number, only a limit; the forecaster's own chance of this, stated with the estimate: 80%; the middle value lies beyond the limit too.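

Compound 4 gives only a limit in this assay, so its steps from compound 1, compound 2 and compound 3 cannot be read, because all four compounds stop at the same limit: the limit of > 25000 nM in this assay, at which 4 of the 4 values shown sit. The compounds shown leave open how the fluoro, methylsulfanyl, carbamoyl and nitro groups compare in this assay and at what concentration any of these compounds would reach its half-maximal effect.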